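The source may report more compounds than this note shows. Statements on the series, on what has been measured and on what is new or still open speak of the compounds shown alone.

Measured compounds:
- Compound 1 `O=S(=O)(c1ccccc1)c1nc2ccccc2nc1N1CCCC1`: 35800 nM
- Compound 2 `Cc1ccc(S(=O)(=O)c2nc3ccccc3nc2N2CCCC2)cc1`: > 50000 nM (a limit)
- Compound 3 `O=S(=O)(c1ccccc1)c1nc2ccccc2nc1N1CCc2ccccc2C1`: 26300 nM

In a functional assay on KB cells (Homo sapiens) for cytotoxicity, read by MTT assay, with a stated time of 72 h (on this read-out lower numbers stand for stronger inhibition and higher numbers for weaker inhibition), compound 3 gives 26300 nM and compound 1 gives 35800 nM, two values within the scatter of each other. Compound 2 is reported only as a limit, not a number: the limit of > 50000 nM in this assay, at which 1 of the 3 values shown sits.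

Compound 4 `O=S(=O)(c1ccc(Br)cc1)c1nc2ccccc2nc1N1CCc2ccccc2C1` differs from compound 3 by bromo in place of hydrogen on an aromatic carbon, on the phenyl of the phenylsulfonyl group: bromo in place of hydrogen on an aromatic carbon.

Among the compounds with values here, the one measured step that bears on this change is methyl in place of hydrogen on an aromatic carbon: an at least 1.3-fold higher number from compound 1 to compound 2 (0.14 log units; that floor lies within the scatter). It is a single step with an open upper end, so it gives only weak guidance and no firm size. No step beyond the scatter is therefore expected in this assay, and no direction is favoured.

The expected change is a 1.1-fold higher number from compound 3 to compound 4 (0.03 log units; within the scatter). For compound 4 the estimated value is 28000 nM, with an expected range of 13000 nM to 50000 nM.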

Compound 4, half-maximal inhibitory concentration: > 50000 nM
Compound 4 ended at the assay's limit; the forecaster's own chance of this, stated with the estimate: 25%; middle value at least 1.7-fold (0.25 log units) away from the limit.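

The bromo change on the phenyl of the phenylsulfonyl group gives, in this assay, an at least 1.9-fold higher number from compound 3 to compound 4 (0.27 log units; that floor lies within the scatter), a second open-ended step on this phenyl alongside an at least 1.3-fold higher number from compound 1 to compound 2 (0.14 log units; that floor lies within the scatter). Compound 4 is reported only as a limit, as is compound 2: the limit of > 50000 nM in this assay, at which 2 of the 4 values shown sit. Methyl and bromo, each carried on a different amine substituent of the shared core, therefore both end at the limit rather than at a number, yet neither floor lies beyond the scatter, so a real loss of activity on substitution at this phenyl is not established.

Going by these compounds, how far either step truly reaches stays unknown. Also open, on these data alone, is whether a carboxylic acid, an amine or a methoxy group on this phenyl would give a value inside the assay's range.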